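A few compounds are considered here, and "the series" means these few. Any claim that something is new, unique, unknown or untested is made for them only; others in the source may bear on it.

Measured so far:
compound 1, `CCC(=O)Nc1ccc(S(=O)(=O)Oc2ccccc2C(C)C)cc1`; in a functional assay on MCF7 cells (Homo sapiens) for antiproliferative activity, read by sulforhodamine B assay, with a stated time of 48 h (on this read-out higher numbers stand for weaker inhibition and lower numbers for stronger inhibition), compound 1 gives 11000 nM.
compound 2, `CCCNC(=O)Nc1ccc(S(=O)(=O)Oc2ccccc2I)cc1`; in this assay compound 2 gives 2900 nM.

Of the two numbers, compound 1 has the higher one, so it is the weaker inhibitor of the pair, and the gap to compound 2 is larger than the scatter of repeated measurements. Compound 1 and compound 2 differ in more than one place, so no single structural change can be tied to that gap; only the two values themselves can be compared.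

The next compound, compound 3, `CC(C)c1ccccc1OS(=O)(=O)c1ccc(NC(=O)NCCCCl)cc1`, differs from compound 1 in exactly one place: (3-chloropropyl)amino in place of ethyl on a carbonyl carbon. Within the data shown here, no step between two measured compounds that differ only in this way is available, so the expectation rests on little. A modest step in this assay toward lower numbers, that is toward stronger inhibition, seems plausible, though it may also turn out to lie within the scatter. Compound 3 is therefore expected to give about 4500 nM, between 1500 nM and 14000 nM. That estimate means an expected step of a 2.4-fold lower number from compound 1 to compound 3 (0.39 log units; beyond the scatter).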

Compound 3, half-maximal inhibitory concentration: 7400 nM
Beside the measured number, compound 3's estimate is 1.6-fold (0.22 log units) below it; measured number inside the range.
By their numbers in this assay, from the lowest: compound 2; then compounds 3 and 1 (each within the scatter of the next).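

In this assay, among these compounds, turning the propanoylamino group of compound 1 into ((3-chloropropyl)carbamoyl)amino gives a 1.5-fold lower number from compound 1 to compound 3 (0.17 log units; within the scatter) and is the first single-place comparison available at this position. Even though the entering group brings a nitrogen, a chlorine, a hydrogen-bond donor and a longer chain, the numbers of the two compounds cannot be told apart, so this position accepts this particular exchange without a measurable penalty or gain in this test of cell growth. No measurement at hand accounts for this outcome.

As far as these compounds go, a single step cannot separate the contributions of the nitrogen, the chlorine and the chain, so whether any of them matters alone, or whether opposing contributions happen to cancel, stays open. From the compounds shown here alone, it also remains open what a plain propylamino group on the core of compound 1, a shorter (2-chloroethyl)amino group, a longer chloroalkyl chain or a terminal amine would give on this carbonyl carbon.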